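A few compounds are considered here, and "the series" means these few. Any claim that something is new, unique, unknown or untested is made for them only; others in the source may bear on it.

Measured set in a functional assay on HCT-116 cells (Homo sapiens) for antiproliferative activity, read by sulforhodamine B assay, with a stated time of 72 h; a higher number here means a weaker inhibitor, a lower number a stronger inhibitor:
- compound 1 `Cn1ncc(Cl)c1-c1cc(C(=O)N[C@@H]2CN[C@H](CC(O)CO)C[C@H]2c2ccc(Cl)c(Cl)c2)oc1Cl`: 1110 nM
- compound 2 `CCC[C@@H]1C[C@@H](c2ccc(Cl)c(Cl)c2)[C@H](NC(=O)c2cc(-c3c(Cl)cnn3C)c(Cl)o2)CN1`: 1020 nM
- compound 3 `Cn1ncc(Cl)c1-c1cc(C(=O)N[C@@H]2CN[C@H](CC(=O)NC3CC3)C[C@H]2c2ccc(Cl)c(Cl)c2)oc1Cl`: 740 nM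

Compound 1 gives the highest of the three numbers, though its gaps to compound 2 and compound 3 are both within the scatter, so no order among them is claimed. Compound 4 `Cn1ncc(Cl)c1-c1cc(C(=O)N[C@@H]2CN[C@H](CCN3CCCC3)C[C@H]2c2ccc(Cl)c(Cl)c2)oc1Cl` differs from compound 1 at one place: (pyrrolidin-1-yl)methyl in place of 1,2-dihydroxyethyl on a saturated chain carbon bound to a saturated ring carbon. The two steps that bear on this are those that likewise replace the 1,2-dihydroxyethyl at the same place, a 1.1-fold lower number from compound 1 to compound 2 (0.04 log units; within the scatter) and a 1.5-fold lower number from compound 1 to compound 3 (0.18 log units; within the scatter); a third, a 1.4-fold lower number from compound 2 to compound 3 (0.14 log units; within the scatter), is also within the scatter. No replacement at this place has moved this assay beyond the scatter, so no step beyond the scatter is expected here either, a 1.2-fold lower number from compound 1 to compound 4 (0.09 log units; within the scatter). Compound 4 is estimated at 900 nM in this assay, with a range of 400 nM to 2000 nM.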

Compound 4, half-maximal inhibitory concentration: 1940 nM
Beside the measured number, compound 4's estimate is 2.2-fold (0.33 log units) below it, and the stated range covers the measured number.
By their numbers in this assay, from the lowest: compounds 3, 2, 1 and 4 (each within the scatter of the next, the first and the last beyond it).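

In this assay, among these compounds, a step of a 2.6-fold higher number from compound 3 to compound 4 (0.42 log units; beyond the scatter) is the first at this place to lie beyond the scatter, so replacements on this saturated chain carbon can separate. That separation is limited to 2-(pyrrolidin-1-yl)ethyl against the cyclopropylcarbamoyl-bearing chain, since steps of a 1.7-fold higher number from compound 1 to compound 4 (0.24 log units; within the scatter) and a 1.9-fold higher number from compound 2 to compound 4 (0.28 log units; within the scatter) stay within the scatter. No evidence at hand accounts for this gap. Still open, as far as these compounds go, is how a carboxylic acid, a primary amine or a longer alkyl chain at this place would compare.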